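Notes on the hydroxyphenyl analogue of compound 1

The compounds below may be only part of what the source reports. "The series", "measured", "known", "first", "only" and "open" are said of these compounds alone.

Measured so far in a functional assay on TREX cells for negative allosteric modulation of metabotropic glutamate receptor 3 (Rattus norvegicus), read by calcium flux, with a stated time of 2.5 min; on this read-out lower numbers stand for stronger inhibition and higher numbers for weaker inhibition:
compound 1 `CCOc1ccc(C#Cc2ccc(C(=O)N3CCC[C@@H](CO)C3)cc2)cc1` — > 10000 nM
compound 2 `COc1ccc(-c2nnc(-c3ccc(C(=O)N4CCC[C@@H](CO)C4)cc3)o2)cc1` — > 10000 nM

In this assay compound 1 gives > 10000 nM, which is a limit of the assay and not a number. Compound 2 gives > 10000 nM in this assay, again a limit. Among the compounds with values here, compound 1 therefore stands at the limit, as does the one other value shown, both sitting at the limit of > 10000 nM in this assay, at which 2 of the 2 values shown sit. Within the data shown here, no two measured compounds differ in a single place, so no measured step is available for this series.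

Compound 3 `O=C(c1ccc(C#Cc2ccc(O)cc2)cc1)N1CCC[C@@H](CO)C1` differs from compound 1 by hydrogen in place of ethyl on an oxygen on an aromatic ring. Whether hydrogen in place of ethyl on an oxygen on an aromatic ring moves the read-out in this assay cannot be told from compound 1 and compound 2, which both sit at the limit. For compound 3 the expected step is a step that the limit leaves unreadable from compound 1 to compound 3, with no direction beyond the scatter. Compound 3 is estimated at 15000 nM, within 3000 nM to 60000 nM, most likely reported again as a limit.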

Compound 3, half-maximal inhibitory concentration: > 10000 nM
Compound 3: a limit, no number; the forecaster's own chance of this, stated with the estimate: 75%; the middle value does not contradict the limit.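

No step can be read from compound 1 to compound 3, because both sit at the same limit of the assay, which is not a number: the limit of > 10000 nM in this assay, at which 3 of the 3 values shown sit.

The compounds shown leave open whether ethoxy or hydroxy on the shared core makes any difference to inhibition in this assay.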